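Notes on the series: from compound 2 toward compound 4

The source may hold more compounds than are shown below. What is called first, only, known or untested is meant among the compounds shown, and "the series" means these compounds.

Compound 2 `CN(C(=O)NC(=O)c1ccccc1F)c1nc(C(F)(F)F)c(C(=O)N/N=C/c2ccc(C(F)(F)F)cc2)s1` gives 3.87 ug/mL in a functional assay on BCG823 cells (Homo sapiens) for inhibition, read by MTT assay, with a stated time of 72 h (on this read-out lower numbers stand for stronger inhibition and higher numbers for weaker inhibition), the lowest of the three numbers in hand, although compound 1 `CN(C(=O)NC(=O)c1cccc(C(F)(F)F)c1)c1nc(C(F)(F)F)c(C(=O)N/N=C/c2cccc(C(F)(F)F)c2)s1` at 4.6 ug/mL and compound 3 `CN(C(=O)NC(=O)c1ccccc1F)c1nc(C(F)(F)F)c(C(=O)N/N=C/c2ccccc2C(F)(F)F)s1` at 4.67 ug/mL both lie within the scatter of it, so no ranking among the three is claimed. Compound 4 `CN(C(=O)NC(=O)c1ccc(F)c(F)c1)c1nc(C(F)(F)F)c(C(=O)N/N=C/c2ccc(C(F)(F)F)cc2)s1` differs from compound 2 by 3,4-difluorophenyl in place of 2-fluorophenyl on a carbonyl carbon. For the measured compounds named here, the only single-point step measured, a 1.2-fold higher number from compound 2 to compound 3 (0.08 log units; within the scatter), concerns the aryl on the carbon with a double bond to nitrogen, not the carbonyl side, and compound 1 differs from compound 2 in two places at once; neither bears directly on the present change. The step to compound 4 is therefore expected to be a 1.1-fold higher number from compound 2 to compound 4 (0.04 log units; within the scatter), nothing beyond the scatter. For compound 4 the estimate is 4.2 ug/mL, within a range from 2 ug/mL to 9 ug/mL.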

Compound 4, half-maximal inhibitory concentration: 3.85 ug/mL
For compound 4 the middle estimate is 1.1-fold (0.04 log units) above the measured one; measured number inside the range.
By their numbers in this assay, from the lowest: compounds 4, 2, 1 and 3 (each within the scatter of the next).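

On a carbonyl carbon whose other neighbour is an amide-type nitrogen, 3,4-difluorophenyl in place of 2-fluorophenyl gives a 1.0-fold lower number from compound 2 to compound 4 (0.00 log units; within the scatter) in this assay. This is the only single-point step shown on the carbonyl side, and it leaves the number unchanged within the scatter, so this exchange of fluorinated phenyl groups does not separate the two compounds. Nothing available accounts for this result.

The compounds shown leave open whether a more different group at this place, such as an amine, a carboxylic acid or a longer chain in place of the fluorinated phenyl, would give a step beyond the scatter.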